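Ester swap on the thiophene analogue: working expectation

This account rests on a few compounds, and the source may have more. Where it says the series, first, only, none or still open, it means among the compounds named here.

Of the compounds shown here, three on a shared core have been measured, all with one change at a time. Compound 1 `CC1=C(C(=O)OCC(C)C)C(c2ccco2)NC(=O)N1C` carries an isobutyl ester, and in an assay on membranes from CHO cells for displacement of a labelled ligand from adenosine receptor A1 (Homo sapiens), read by scintillation counting, with a stated time of 60 min, tested at 1 uM (a higher number here means more inhibition at the concentration tested (going by the name of the read-out), a lower number less inhibition), compound 1 gives 13%. Compound 2 `CC1=C(C(=O)OC(C)(C)C)C(c2ccco2)NC(=O)N1C` differs from compound 1 by tert-butyl in place of isobutyl on an oxygen next to a carbonyl group, and in this assay compound 2 gives 44%. Among the compounds with values here, the resulting step, a number 31 percentage points higher from compound 1 to compound 2 (beyond the scatter), is the only measured instance of this ester change so far. Compound 3 `CC1=C(C(=O)OCC(C)C)C(c2ccsc2)NC(=O)N1C` keeps the isobutyl ester, but its core differs from the core of compound 1 by thiophen-3-yl in place of furan-2-yl on a saturated ring carbon; in this assay compound 3 gives 8%. The step of a number 5 percentage points lower from compound 1 to compound 3 (within the scatter) gives no ground to separate compound 1 and compound 3 on this read-out.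

Compound 4 `CC1=C(C(=O)OC(C)(C)C)C(c2ccsc2)NC(=O)N1C` is not yet measured. It differs from compound 3 by tert-butyl in place of isobutyl on an oxygen next to a carbonyl group, the same change that leads from compound 1 to compound 2, at the same place word for word; it occurs twice among these four compounds. The two pairs differ only in the aromatic group on the saturated ring carbon, as just described.

Within the data shown here, the step of a number 25 percentage points higher from compound 3 to compound 4 (beyond the scatter) is expected for compound 4 because a number 31 percentage points higher from compound 1 to compound 2 (beyond the scatter) stands as the single measured example of this change, with some allowance for a smaller gain on the thiophene core. In this assay compound 4 is therefore estimated at 33%, with a range from 15% to 55%.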

Compound 4, a percentage reported as inhibition, at one concentration (the size of the read-out at that concentration, not a potency): 18%
Beside the measured number, compound 4's estimate is 15 percentage points above it; measured number inside the range.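

In this assay, tert-butyl in place of isobutyl on an oxygen next to a carbonyl group does not carry over from the furan-2-yl pair to the thiophen-3-yl pair at the same size; on the latter the step is a number 10 percentage points higher from compound 3 to compound 4 (within the scatter), and the two steps differ: the same change on two cores in this assay, a number 31 percentage points higher (beyond the scatter) from compound 1 to compound 2 and a number 10 percentage points higher (within the scatter) from compound 3 to compound 4, 21 percentage points apart, beyond the scatter of two such steps. The same four compounds read the other way show that thiophen-3-yl in place of furan-2-yl, which separates nothing with the isobutyl ester, gives a number 26 percentage points lower from compound 2 to compound 4 (beyond the scatter) with the tert-butyl ester, so this change too depends on its partner: the same change on two cores in this assay, a number 5 percentage points lower (within the scatter) from compound 1 to compound 3 and a number 26 percentage points lower (beyond the scatter) from compound 2 to compound 4, 21 percentage points apart, beyond the scatter of two such steps. The two changes therefore do not add up independently across these four compounds, but this rests on a single pair per core at one concentration, gives no potency and does not show why the steps differ.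

The compounds shown leave open whether the tert-butyl gain belongs to furan-2-yl alone or also appears with other aromatic groups on the saturated ring carbon, such as phenyl or thiophen-2-yl. They also leave open how other groups in the ester position, such as an ethyl ester or a cyclopentyl ester, would behave on either core.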